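Replacing Chloro with Methoxy in Compound 2

A few compounds are considered here, and "the series" means these few. Any claim that something is new, unique, unknown or untested is made for them only; others in the source may bear on it.

Compound 2 `Cc1cnc(Oc2cc(Cl)c(F)c(-c3ccc4c(c3)CC[C@H](CCC(=O)O)O4)c2)s1` in a functional assay on HEK293 cells for agonist activity at Free fatty acid receptor 1 (Homo sapiens), read by HTRF and inositol phosphate accumulation, with a stated time of 60 min (a higher number here means that more compound is needed for the effect, a lower number that less compound is needed), gives > 10000 nM, which is a limit of the assay rather than a number. Compound 3 `O=C(O)CC[C@H]1CCc2cc(-c3cc(OC4CCC4)cc(Cl)c3F)ccc2O1` likewise gives > 10000 nM, again a limit. Compound 1 `O=C(O)CC[C@H]1CCc2cc(-c3cc(OC(F)(F)F)cc(Cl)c3F)ccc2O1` gives 2200 nM. The steps of an at least 4.5-fold higher number from compound 1 to compound 2 (0.65 log units; beyond the scatter) and an at least 4.5-fold higher number from compound 1 to compound 3 (0.65 log units; beyond the scatter) are read against (the limit of > 10000 nM in this assay, at which 2 of the 3 values shown sit), and a step that the two limits leave unreadable from compound 2 to compound 3. Compound 4 `COc1cc(Oc2ncc(C)s2)cc(-c2ccc3c(c2)CC[C@H](CCC(=O)O)O3)c1F` differs from compound 2 by methoxy in place of chloro on an aromatic carbon. Among the measured compounds shown here, none of the measured steps involves the chloro group; all three vary the group on the oxygen. For the measured compounds named here, no measured step therefore sets the size of this change, and compound 2 itself stands only at a limit. Compound 4 is expected to remain near that limit, with a step that the limit leaves unreadable from compound 2 to compound 4 anticipated and an estimate of 12000 nM spanning 3000 nM to 40000 nM.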

Compound 4, half-maximal effective concentration: > 10000 nM
Compound 4 gave a limit, no number (the forecaster's own chance of this, stated with the estimate: 70%); the middle value does not contradict the limit.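

No step can be read from compound 2 to compound 4, because each stands only at a limit: the limit of > 10000 nM in this assay, at which 3 of the 4 values shown sit. The compounds shown leave open whether methoxy in place of chloro changes the concentration needed at all.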